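The source may hold more compounds than are shown below. What is called first, only, known or untested is meant among the compounds shown, and "the series" means these compounds.

Compound 1 `CNc1ccnc2c1ncn2[C@@H]1O[C@H](CO)[C@](O)(CO)[C@H]1O` and compound 2 `Nc1ccn([C@@H]2O[C@H](CO)[C@](O)(CO)[C@H]2O)c(=O)n1` share the same sugar-like portion but carry different flat ring systems; how the two cores differ is not broken down here. In an ADME assay on Huh-7 cells (Homo sapiens) for cytotoxicity, read by WST assay, with a stated time of 3 days (on this read-out higher numbers stand for lower toxicity in this test and lower numbers for higher toxicity in this test), compound 1 gives 11800 nM, and compound 2 gives 12300 nM. Compound 3 `CNc1ccnc2c1ncn2[C@@H]1O[C@H](CO)[C@](O)(CF)[C@H]1O` is compound 1 after (fluoro in place of hydroxy on a saturated chain carbon bound to a saturated ring carbon). For compound 3 this assay reports only a limit, > 100000 nM. The change therefore produced an at least 8.4-fold higher number from compound 1 to compound 3 (0.92 log units; beyond the scatter), and the step can only be given as a lower bound because the limit of > 100000 nM in this assay, at which 1 of the 3 values shown sits, caps what the measurement can show.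

Compound 4 `Nc1ccn([C@@H]2O[C@H](CO)[C@](O)(CF)[C@H]2O)c(=O)n1` is the corresponding partner of compound 2, reached through (fluoro in place of hydroxy on a saturated chain carbon bound to a saturated ring carbon), the same change made at the same place. Since compound 2 and compound 1 sit so close in this assay, the step is expected to repeat: for compound 4 the estimated change is an 8.1-fold higher number from compound 2 to compound 4 (0.91 log units; beyond the scatter), resting on the measured step from compound 1 to compound 3. Compound 4 is thus expected to give about 100000 nM in this assay, plausibly ranging from 40000 nM to 300000 nM, with a fair chance that only a limit is reported.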

Compound 4, half-maximal cytotoxic concentration: > 100000 nM
Compound 4 ended at the assay's limit; the forecaster's own chance of this, stated with the estimate: 65%; the middle value sits exactly at the limit.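

In this assay, replacing hydroxymethyl with fluoromethyl on the core of compound 2 gives an at least 8.1-fold higher number from compound 2 to compound 4 (0.91 log units; beyond the scatter), so the change points the same way on both cores, toward lower toxicity in this test: the same change on two cores in this assay, an at least 8.4-fold higher number (0.92 log units; beyond the scatter) from compound 1 to compound 3 and an at least 8.1-fold higher number (0.91 log units; beyond the scatter) from compound 2 to compound 4; the limit leaves it open whether they differ

Compound 4 gives > 100000 nM, and this is a limit of the assay, not an exact number.

The true size of each step therefore stays unknown, and the data cannot show whether one core responds more strongly than the other, because both fluoromethyl compounds end at the same limit: the limit of > 100000 nM in this assay, at which 2 of the 4 values shown sit.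

Two cores are also too few to support a rule for the wider series. On these data alone, it remains open how an amine, a methoxy group or a chlorine in place of the hydroxy would affect the reading, and whether the fluoro change would have the same effect on other cores.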